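A few compounds are considered here, and "the series" means these few. Any claim that something is new, unique, unknown or untested is made for them only; others in the source may bear on it.

Compound 1 `CNC(=O)CCCCCCCn1nc(-c2cnc3[nH]ccc3c2)c2c(N)ncnc21` — 7570 nM
Compound 2 `Nc1ncnc2c1c(-c1cnc3[nH]ccc3c1)nn2CC(=O)NO` — > 150000 nM
Compound 3 `Nc1nc2cc(-c3nn(CC(=O)NO)c4ncnc(N)c34)ccc2o1` — > 100000 nM

Of the compounds shown here, three have been measured in a functional assay on MCF7 cells (Homo sapiens) for inhibition, read by MTT assay, with a stated time of 72 h; on this read-out lower numbers stand for stronger inhibition and higher numbers for weaker inhibition. Compound 1 gives 7570 nM in this assay. For compound 2 the result in this assay is only a limit, > 150000 nM. For compound 3 the result in this assay is likewise only a limit, > 100000 nM.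

Compound 1 and compound 2 share a core and differ in one place: 6-(methylcarbamoyl)hexyl in place of hydroxycarbamoyl on a saturated chain carbon bound to an aromatic nitrogen. The step of an at least 19-fold lower number from compound 2 to compound 1 (1.29 log units; beyond the scatter) is large, and since compound 2 sits at a limit (the limit of > 150000 nM in this assay, at which 1 of the 3 values shown sits), its true size is open upward.

Compound 4 `CNC(=O)CCCCCCCn1nc(-c2ccc3oc(N)nc3c2)c2c(N)ncnc21` has not yet been measured in this assay. It relates to compound 3 through the same change that turns compound 2 into compound 1: 6-(methylcarbamoyl)hexyl in place of hydroxycarbamoyl on a saturated chain carbon bound to an aromatic nitrogen. The difference between the core of compound 3 and the core of compound 2 is not broken down here. Compound 3 also sits at a limit (the limit of > 100000 nM in this assay, at which 1 of the 3 values shown sits), so the starting point of the new step is itself unknown.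

Because the same change gave the step of an at least 19-fold lower number from compound 2 to compound 1 (1.29 log units; beyond the scatter), compound 4 is expected to show a step of similar direction, estimated as an at least 10-fold lower number from compound 3 to compound 4 (1.00 log units; beyond the scatter), with wide uncertainty since compound 3 was measured only as a limit. The expected value for compound 4 in this assay is 10000 nM, between 2500 nM and 60000 nM.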

Compound 4, half-maximal inhibitory concentration: 7220 nM
Compound 4: the middle estimate sits 1.4-fold (0.14 log units) above what was measured; low and high end bracket the measured number.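

In this assay, replacing hydroxycarbamoyl with 6-(methylcarbamoyl)hexyl on the saturated chain carbon bound to an aromatic nitrogen carries over to the second core in direction, with an at least 13-fold lower number from compound 3 to compound 4 (1.14 log units; beyond the scatter), and the two products with this group sit close together, with a 1.0-fold lower number from compound 1 to compound 4 (0.02 log units; within the scatter). Set beside the first case, the change reads as follows: the same change on two cores in this assay, an at least 19-fold lower number (1.29 log units; beyond the scatter) from compound 2 to compound 1 and an at least 13-fold lower number (1.14 log units; beyond the scatter) from compound 3 to compound 4; the limit leaves it open whether they differ. Compound 3 gives only a limit, > 100000 nM, so these compounds show a shared direction on two cores but not a shared size, and two cores make no rule for the whole series.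

From the compounds shown here alone, the change alters chain length and end group at once, so it remains open whether the lower numbers follow the longer chain or the methylcarbamoyl end, a question that a 6-(hydroxycarbamoyl)hexyl group, or a methylcarbamoyl group on the short chain, would bear on. Also open, going by these compounds, are how a carboxylic acid or an amine at the end of the hexyl chain would read in this assay, and whether the step would hold on any core other than these two.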